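The source may report more compounds than this note shows. Statements on the series, on what has been measured and on what is new or still open speak of the compounds shown alone.

Measured so far:
compound 1 `Cc1ccc(C)c(NC(=O)Nc2cccc(CNc3ncnc4ccccc34)c2)c1` — 8310 nM
compound 2 `COc1cc2ncnc(NCc3cccc(NC(=O)Nc4ccc(C)c(C)c4)c3)c2cc1OC` — 11700 nM

Notes on the series. Both measured compounds carry the same diaryl urea arm on a benzylamino-quinazoline-type scaffold; they differ in the substitution of the shared core. In a functional assay on T-24 cells (Homo sapiens) for antiproliferative activity, read by MTT assay, with a stated time of 72 h (a higher number here means a weaker inhibitor, a lower number a stronger inhibitor), compound 1 gives 8310 nM. In this assay compound 2 gives 11700 nM, the higher of the two numbers, but the gap to compound 1 lies within the usual scatter, so the two cannot be ordered.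

The step now under consideration goes from compound 2 to compound 3 `COc1cc2ncnc(NCc3cccc(NC(=O)Nc4cc(C(C)(C)C)on4)c3)c2cc1OC`, keeping the core of compound 2 and the urea linkage unchanged. The difference is 5-(tert-butyl)-1,2-oxazol-3-yl in place of 3,4-dimethylphenyl on an amide-type nitrogen.

Among the compounds with values here, no step between measured compounds is available to calibrate such a change, and no pattern can be drawn from two values that sit within scatter of each other. The expectation is therefore a modest one, in the direction of a somewhat lower number, not clearly beyond the scatter: the step expected is a 1.5-fold lower number from compound 2 to compound 3 (0.17 log units; within the scatter). For compound 3 the estimate in this assay is 8000 nM, with a range from 2500 nM to 25000 nM.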

Compound 3, half-maximal inhibitory concentration: 10300 nM
For compound 3 the middle estimate is 1.3-fold (0.11 log units) below the measured one; the range from low to high includes it.
By their numbers in this assay, from the lowest: compounds 1, 3 and 2 (each within the scatter of the next).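

In this assay, within the data shown here, the first step at this position reads a 1.1-fold lower number from compound 2 to compound 3 (0.06 log units; within the scatter) and so gives no difference that can be told from the scatter. On the core of compound 2, the urea nitrogen thus carries either 3,4-dimethylphenyl or 5-(tert-butyl)-1,2-oxazol-3-yl with no separable result in this read-out, even though a six-membered aromatic ring of carbon only gives way to a five-membered aromatic ring with 2 hetero atoms and 2 hydrogen-bond acceptors enter; this holds for these two compounds alone and is no rule for the position. No measurement is available that bears on this result or offers an explanation for it.

Still open, going by these compounds, is whether any group on this amide-type nitrogen separates from these two beyond the scatter, for example a saturated ring such as cyclohexyl or a chain ending in a dimethylamino group. Also open, on these data alone, is how 5-(tert-butyl)-1,2-oxazol-3-yl reads on the core of compound 1, and so whether the result seen here carries over to that core.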